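This account rests on a few compounds, and the source may have more. Where it says the series, first, only, none or still open, it means among the compounds named here.

Measured in a functional assay on HepG2 cells (Homo sapiens) for inhibition, read by MTT assay, with a stated time of 120 h; a higher number here means a weaker inhibitor, a lower number a stronger inhibitor:
- compound 1 `O=C(/C=C/c1ccc(NC(=O)Nc2ccc(Cl)c(C(F)(F)F)c2)cc1)NC1CCC1`: 7510 nM
- compound 2 `CC(NC(=O)c1cccc(-c2ccc(NC(=O)Nc3ccc(Cl)c(C(F)(F)F)c3)cc2)c1)c1ccccc1`: 5670 nM
- compound 3 `CC(NC(=O)c1ccc(-c2ccc(NC(=O)Nc3cc(C(F)(F)F)ccc3Cl)cc2)cc1)c1ccccc1`: 18400 nM

Compound 1, at 7510 nM, holds the second highest of the three numbers in this assay. Its number lies within the scatter of that of compound 2, while compound 3 gives a higher number, beyond the scatter.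

Compound 4 `CNC(=O)C#Cc1ccc(NC(=O)Nc2ccc(Cl)c(C(F)(F)F)c2)cc1` keeps the core of compound 1 and carries 2-(methylcarbamoyl)ethynyl in place of 2-(cyclobutylcarbamoyl)ethenyl on an aromatic carbon, para to a large group: 2-(methylcarbamoyl)ethynyl in place of 2-(cyclobutylcarbamoyl)ethenyl on an aromatic carbon. Among the compounds with values here, no measured pair shows what this change does, so any expectation is only loosely supported. The three measured compounds all give numbers of the same broad order, and compound 1 at 7510 nM is the closest reference for compound 4. The expected step is a 1.3-fold lower number from compound 1 to compound 4 (0.10 log units; within the scatter), which would be none beyond the scatter in this assay. For compound 4 the estimated value is 6000 nM, with an expected range from 1500 nM to 20000 nM.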

Compound 4, half-maximal inhibitory concentration: 23300 nM
Estimate against measurement, compound 4: 3.9-fold (0.59 log units) below, and the stated range ends below it.
By their numbers in this assay, from the lowest: compounds 2 and 1 (each within the scatter of the next); then compounds 3 and 4 (each within the scatter of the next).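

In this assay, 2-(methylcarbamoyl)ethynyl in place of 2-(cyclobutylcarbamoyl)ethenyl gives a 3.1-fold higher number from compound 1 to compound 4 (0.49 log units; beyond the scatter) and so shows that the number responds to the group on this aromatic carbon. The change is compound, as the four-membered ring leaves, the group goes from 9 heavy atoms to 6, and a triple bond enters, while the counts of hydrogen-bond donors and acceptors stay the same. No measurement available here assigns the step to any one of these parts.

The compounds shown leave open whether the step follows the ethynyl link or the exchange of cyclobutyl for methyl on the amide nitrogen. They also leave open how a carboxylic acid or an amine at this position would read in this assay.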